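The compounds below may be only part of what the source reports. "The series", "measured", "known", "first", "only" and "open" are said of these compounds alone.

Measured so far in a functional assay on SW-620 cells (Homo sapiens) for cytotoxicity, read by MTT assay, with a stated time of 72 h; on this read-out higher numbers stand for weaker inhibition and lower numbers for stronger inhibition:
Compound 1 `COc1cccc(/C=C2\CCC/C(=C\c3ccc(O)cc3)C2=O)c1OC`: > 20000 nM (a limit, not a number)
Compound 2 `COc1cccc(/C=C2\CCC/C(=C\c3cccc(Cl)c3Cl)C2=O)c1OC`: 16300 nM

Compound 1 gives > 20000 nM, which is a limit of this assay. For the measured compounds named here, that leaves compound 2, at 16300 nM, with the only actual number so far. Going by the values given here, the single measured step is an at least 1.2-fold lower number from compound 1 to compound 2 (0.08 log units; that floor lies within the scatter). It starts from the limit of > 20000 nM in this assay, at which 1 of the 2 values shown sits, so it gives no firm size for a change at this place.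

The next compound, compound 3 `COc1cccc(/C=C2\CCC/C(=C\c3ccc(Cl)cc3Cl)C2=O)c1OC`, differs from compound 2 by 2,4-dichlorophenyl in place of 2,3-dichlorophenyl on a double-bonded chain carbon bound to a double-bonded ring carbon. The two have the same atoms, joined differently: 2,4-dichlorophenyl in place of 2,3-dichlorophenyl. Among the compounds with values here, no measured step compares two dichlorophenyl groups, so the main guide is compound 2 at 16300 nM. No change beyond the scatter is therefore expected, in either direction. The expected change is a 1.2-fold lower number from compound 2 to compound 3 (0.07 log units; within the scatter), which is only an estimate. The estimate for compound 3 is 14000 nM, with an expected range from 6000 nM to 20000 nM.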

Compound 3, half-maximal inhibitory concentration: 16300 nM
Estimate against measurement, compound 3: 1.2-fold (0.07 log units) below, within the range that was stated.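

Shifting a chlorine on the ring while keeping the same atoms has no visible effect in this assay, where 2,4-dichlorophenyl in place of 2,3-dichlorophenyl gives no change at the digits printed from compound 2 to compound 3 (within the scatter) at this place on the double-bonded chain carbon. For the compounds shown here, this is the first comparison of two dichlorophenyl groups here, and this read-out does not tell these two arrangements of chlorine apart. The value of compound 1 is a limit, not a number, so the change from 4-hydroxyphenyl to 2,4-dichlorophenyl, which gives an at least 1.2-fold lower number from compound 1 to compound 3 (0.08 log units; that floor lies within the scatter), has no firm size: the limit of > 20000 nM in this assay, at which 1 of the 3 values shown sits.

It remains open whether any group at this place can move the number beyond the scatter, since no step shown so far does so with a firm size. A phenyl ring carrying a single chlorine, an amine or a carboxylic acid would test this, and replacing the 2,3-dimethoxyphenyl group, which stays the same in all three compounds, would show whether the other side of the shared core matters more.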